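A few compounds are considered here, and "the series" means these few. Any claim that something is new, unique, unknown or untested is made for them only; others in the source may bear on it.

Working notes on the series. Compound 1 `COc1cc2ncnc(Nc3cccc(Br)c3)c2cc1OCCCCC(=O)Nc1ccc(S(N)(=O)=O)cc1` and compound 2 `COc1cc2ncnc(Nc3ccc(F)c(Br)c3)c2cc1OCCCCC(=O)Nc1ccc(S(N)(=O)=O)cc1` share one core and differ at a single aromatic carbon. In a functional assay on A549 cells (Homo sapiens) for antiproliferative activity, read by MTT assay, with a stated time of 72 h (a lower number here means a stronger inhibitor, a higher number a weaker inhibitor), compound 1 gives 14900 nM. In this assay compound 2 gives 16000 nM. The change between them is hydrogen in place of fluoro on an aromatic carbon and it produced a 1.1-fold lower number from compound 2 to compound 1 (0.03 log units; within the scatter); the two values are therefore to be read as indistinguishable.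

Compound 3 `NS(=O)(=O)c1ccc(NC(=S)Nc2ccc3ncnc(Nc4ccc(F)c(Br)c4)c3c2)cc1` is built on a different core, and the difference between the two cores is not broken down here. In this assay compound 3 gives only a limit, > 40000 nM, and no number.

Compound 4 `NS(=O)(=O)c1ccc(NC(=S)Nc2ccc3ncnc(Nc4cccc(Br)c4)c3c2)cc1` has not yet been measured in this assay. It stands to compound 3 exactly as compound 1 stands to compound 2: the change is hydrogen in place of fluoro on an aromatic carbon, the same change, made on the core of compound 3 rather than that of compound 1. Among the compounds here this change occurs twice, once measured and once pending. For compound 4 the expected step in this assay is a step that the limit leaves unreadable from compound 3 to compound 4, and that expectation rests on a 1.1-fold lower number from compound 2 to compound 1 (0.03 log units; within the scatter) having stayed within the scatter. A result reported only as a limit is the likelier outcome, given (the limit of > 40000 nM in this assay, at which 1 of the 3 values shown sits). Compound 4 is thus estimated at 45000 nM in this assay, with a range from 18000 nM to 120000 nM.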

Compound 4, half-maximal inhibitory concentration: 25000 nM
Compound 4: middle estimate off by 1.8-fold (0.26 log units), on the high side; measured number inside the range.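

On the core of compound 3, hydrogen in place of fluoro gives in this assay an at least 1.6-fold lower number from compound 3 to compound 4 (0.20 log units; that floor lies within the scatter), so the floor of this step does not by itself separate the change from the usual scatter of repeated measurements. Compound 3 is reported only as a limit, > 40000 nM, which is not a number, so the step on this core has a floor and no measured size. Carrying the change from the core of compound 1 to the core of compound 3 therefore shows neither that the step is preserved nor that it depends on the core, and the one comparison available stays unresolved: the same change on two cores in this assay, a 1.1-fold lower number (0.03 log units; within the scatter) from compound 2 to compound 1 and an at least 1.6-fold lower number (0.20 log units; that floor lies within the scatter) from compound 3 to compound 4; the limit leaves it open whether they differ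

The compounds shown leave open how a chloro or a methoxy group would read on either core at the aromatic carbon that carries fluoro in compound 2 and compound 3. They also leave open what a number for compound 3 would make of the step, and how the two cores compare with each other, since no pair shown differs only in the core.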